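A few compounds are considered here, and "the series" means these few. Any claim that something is new, unique, unknown or untested is made for them only; others in the source may bear on it.

Compound 1 `COc1ccc(N(CC(=O)NCCC[Se]c2ccccc2)C(=O)CNC(=O)OC(C)(C)C)cc1` is recorded in an ADME assay on cells (Fibroblast, Homo sapiens) for cytotoxicity, read by MTT assay, with a stated time of 24 h (on this read-out higher numbers stand for weaker inhibition and lower numbers for stronger inhibition), only as a limit of the assay, >= 100000 nM. Compound 2 `COc1ccc(N(CC(=O)NCCCSc2ccccc2)C(=O)/C=C/c2ccccc2)cc1` is likewise recorded only as a limit, >= 100000 nM. Compound 3 `COc1ccc(N(CC(=O)NCCCSc2ccccc2)C(=O)C#Cc2ccccc2)cc1` is also recorded only as a limit, >= 100000 nM.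

Compound 3 therefore stands at the ceiling of this assay, where all three measured compounds sit (the limit of >= 100000 nM in this assay, at which 3 of the 3 values shown sit). Within the data shown here, the only single-point step among them, a step that the two limits leave unreadable from compound 2 to compound 3, cannot be read because both ends are limits. Compound 4 `COc1ccc(N(CC(=O)NCCCSc2ccccc2)C(=O)CNC(=O)OC(C)(C)C)cc1` differs from compound 3 by ((tert-butoxycarbonyl)amino)methyl in place of 2-phenylethynyl on a carbonyl carbon. Compound 1 carries that same entering group and also sits at the limit. Among the measured compounds shown here, no step is readable, so no shift beyond scatter is expected; the estimated step of a number no higher from compound 3 to compound 4 (the limit leaves the size open) is flat. Compound 4 is expected to show 100000 nM, within 50000 nM to 200000 nM.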

Compound 4, half-maximal inhibitory concentration: >= 100000 nM
Compound 4 ended at the assay's limit; the forecaster's own chance of this, stated with the estimate: 85%; the middle value sits exactly at the limit.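

Compound 4 is also recorded only as a limit, so its steps from compound 1, compound 2 and compound 3 cannot be read: the limit of >= 100000 nM in this assay, at which 4 of the 4 values shown sit. The compounds shown leave open what half-maximal concentration any of them has in this assay.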